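Chloro in place of bromo on the aromatic ring

The source may hold more compounds than are shown below. What is called first, only, known or untested is meant among the compounds shown, and "the series" means these compounds.

Compound 1 `Cc1ccc(/C=C2\SC(=O)N(CC(=O)Nc3c(C)n(C)n(-c4ccccc4)c3=O)C2=O)cc1`: 53100 nM
Compound 2 `Cc1c(NC(=O)CN2C(=O)S/C(=C\c3ccc([N+](=O)[O-])cc3)C2=O)c(=O)n(-c2ccccc2)n1C`: 77200 nM
Compound 3 `Cc1c(NC(=O)CN2C(=O)S/C(=C\c3ccc(Br)cc3)C2=O)c(=O)n(-c2ccccc2)n1C`: 9410 nM

In a functional assay on HeLa cells (Homo sapiens) for inhibition, read by MTT assay, with a stated time of 48 h (a lower number here means a stronger inhibitor, a higher number a weaker inhibitor), compound 3 gives 9410 nM, the lowest of the three numbers. Compound 4 `Cc1c(NC(=O)CN2C(=O)S/C(=C\c3ccc(Cl)cc3)C2=O)c(=O)n(-c2ccccc2)n1C` has chloro in place of bromo on an aromatic carbon, para to a large group: chloro in place of bromo on an aromatic carbon. Two measured changes at this place end in bromo: a 5.6-fold lower number from compound 1 to compound 3 (0.75 log units; beyond the scatter) and an 8.2-fold lower number from compound 2 to compound 3 (0.91 log units; beyond the scatter). Both are modest, and neither tests chloro directly. With compound 3 at 9410 nM, the lowest so far, a slight lean upward is expected. The expected step, a 1.5-fold higher number from compound 3 to compound 4 (0.17 log units; within the scatter), is small and may stay within the scatter. Compound 4 is estimated at 14000 nM, with an expected range from 6000 nM to 35000 nM.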

Compound 4, half-maximal inhibitory concentration: 20000 nM
Compound 4: middle estimate off by 1.4-fold (0.15 log units), on the low side; low and high end bracket the measured number.
By their numbers in this assay, from the lowest: compound 3; then compound 4; then compounds 1 and 2 (each within the scatter of the next).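

In this assay, bromo and chloro are not interchangeable at this place on the ring (a 2.1-fold higher number from compound 3 to compound 4 (0.33 log units; beyond the scatter)). Chloro still keeps part of what bromo showed against the other two groups (a 2.7-fold lower number from compound 1 to compound 4 (0.42 log units; beyond the scatter); a 3.9-fold lower number from compound 2 to compound 4 (0.59 log units; beyond the scatter)), so both halogens give lower numbers than methyl and nitro among these four compounds. Nothing available here accounts for the difference between the two halogens. Going by these compounds, whether fluoro, an amine or a methoxy group at this place would fall with the halogens or with methyl and nitro remains open.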